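Removing a Bromo Group: Expected Cytotoxicity of Compound 4

This account rests on a few compounds, and the source may have more. Where it says the series, first, only, none or still open, it means among the compounds named here.

Three compounds have been tested in an ADME assay on HEK293 cells (Homo sapiens) for cytotoxicity, read by reporter gene assay and resazurin assay, with a stated time of 48 h; on this read-out higher numbers stand for lower toxicity in this test and lower numbers for higher toxicity in this test:
compound 1 `COc1c(Br)cccc1C(=O)Nc1ccc(Sc2nc3ccccc3s2)c(Cl)c1`, which gives > 100000 nM, a limit of the assay.
compound 2 `COc1ccc(Br)cc1C(=O)Nc1ccc(Sc2nc3ccccc3s2)cc1`, which gives > 100000 nM, a limit of the assay.
compound 3 `COc1c(Br)cc(Br)cc1C(=O)Nc1ccc(Sc2nc3ccccc3s2)cc1`, which gives > 100000 nM, a limit of the assay.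

Compound 2 therefore stands only at a limit in this assay, not at a number. The same holds for every value shown: the limit of > 100000 nM in this assay, at which 3 of the 3 values shown sit. The single measured step among these compounds, a step that the two limits leave unreadable from compound 2 to compound 3, is consequently not readable in size or direction; it tells nothing about what a bromo group does to the read-out here.

Compound 4 `COc1ccccc1C(=O)Nc1ccc(Sc2nc3ccccc3s2)cc1` is not yet measured in this assay. It differs from compound 2 by hydrogen in place of bromo on an aromatic carbon. Going by the values given here, no measured step bears on this change with a readable size, so nothing in the data points to a shift beyond the scatter in either direction. On that basis compound 4 is expected to give about 100000 nM in this assay, within a range from 50000 nM to 300000 nM. The step of a number no higher from compound 2 to compound 4 (the limit leaves the size open) is thus estimated to be none beyond the scatter, with the most likely outcome that compound 4 also reaches only the limit.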

Compound 4, half-maximal cytotoxic concentration: > 100000 nM
Compound 4 was reported as a limit (the forecaster's own chance of this, stated with the estimate: 85%); the middle value sits exactly at the limit.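

In this assay compound 4 gives > 100000 nM, which is a limit of the assay. No step can be read from compound 2 to compound 4, as neither compound has a number: the limit of > 100000 nM in this assay, at which 4 of the 4 values shown sit.

The compounds shown leave open where any of them would reach a half-maximal cytotoxic concentration, and whether any structural change here shifts it.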